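The source may report more compounds than this note shows. Statements on the series, on what has been measured and on what is new or still open speak of the compounds shown alone.

Series notes. The shared core is that of compound 1 `CN1C[C@H](C(=O)Nc2ccc(C3CC3)cc2)[C@@H](c2ccc(/C=C/C(=O)Nc3ccccc3N)cc2)C1`; compound 2 `CN1C[C@H](C(=O)Nc2ccc(Br)cc2)[C@@H](c2ccc(/C=C/C(=O)Nc3ccccc3N)cc2)C1` and compound 3 `COc1cccc(NC(=O)[C@H]2CN(C)C[C@@H]2c2ccc(/C=C/C(=O)Nc3ccccc3N)cc2)c1` differ from it only in the aryl group carried on the amide-type nitrogen. In an in vitro ADME assay on microsomes from liver (Homo sapiens) for pharmacokinetics, read by LC-MS, with a stated time of 10 min, tested at 1 uM (a lower number here means slower removal, a higher number faster removal of the compound), compound 1 gives 12 mL/min/kg, compound 2 gives 3 mL/min/kg and compound 3 gives 14 mL/min/kg. Compound 1 thus stands second highest of the three numbers: its nearest neighbour is compound 3, with a 1.2-fold higher number from compound 1 to compound 3 (0.07 log units; within the scatter), inside the scatter, and the furthest is compound 2, with a 4.0-fold lower number from compound 1 to compound 2 (0.60 log units; beyond the scatter), beyond it.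

The step to compound 4 `CN1C[C@H](C(=O)Nc2ccc(F)c(Cl)c2)[C@@H](c2ccc(/C=C/C(=O)Nc3ccccc3N)cc2)C1` is 3-chloro-4-fluorophenyl in place of 4-cyclopropylphenyl on an amide-type nitrogen. Going by the values given here, two measured steps bear on it. The step of a 4.0-fold lower number from compound 1 to compound 2 (0.60 log units; beyond the scatter), bromo in place of cyclopropyl on an aromatic carbon, gave a modest decrease. The step of a 1.2-fold higher number from compound 1 to compound 3 (0.07 log units; within the scatter), the whole aryl swapped for 3-methoxyphenyl, stayed within the scatter, and the step of a 4.7-fold higher number from compound 2 to compound 3 (0.67 log units; beyond the scatter) moved back up by a modest amount. The 3-chloro-4-fluorophenyl that enters resembles the bromo case of compound 2 more than the methoxy case of compound 3, so the decrease seen there is taken as the nearer precedent.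

For compound 4 a modest decrease is therefore expected, a 2.0-fold lower number from compound 1 to compound 4 (0.30 log units; within the scatter). In this assay compound 4 is estimated at 6 mL/min/kg, within a range from 3 mL/min/kg to 12 mL/min/kg.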

Compound 4, clearance: 15 mL/min/kg
For compound 4 the middle estimate is 2.5-fold (0.40 log units) below the measured one; measured number above the stated range.
By their numbers in this assay, from the lowest: compound 2; then compounds 1, 3 and 4 (each within the scatter of the next).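

In this assay, the change to 3-chloro-4-fluorophenyl on the amide-type nitrogen does not follow the 4-bromophenyl of compound 2: the gap to that compound is beyond the scatter (a 5.0-fold higher number from compound 2 to compound 4 (0.70 log units; beyond the scatter)), whereas the comparisons with the other two aryl groups are within it (a 1.3-fold higher number from compound 1 to compound 4 (0.10 log units; within the scatter) and a 1.1-fold higher number from compound 3 to compound 4 (0.03 log units; within the scatter)). The presence of halogen on the aryl group therefore does not by itself go with the low number at this position, and compound 4 is the direct counterexample to any such reading based on compound 2; among the four aryl groups, 4-cyclopropylphenyl, 3-methoxyphenyl and 3-chloro-4-fluorophenyl cannot be told apart, and only 4-bromophenyl stands apart. No measurement available here accounts for the separation of compound 2 from the other three.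

On these data alone, with a single compound at the low number, it remains open whether that number is specific to the bromo group or extends to other single substituents in its place, such as those of 4-chlorophenyl or 4-fluorophenyl. Also open, as far as these compounds go, is how an aryl group carrying an amine or a carboxylic acid would read at this nitrogen.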